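A Butyl Swap on a Well-Tolerated Compound

The compounds below may be only part of what the source reports. "The series", "measured", "known", "first", "only" and "open" are said of these compounds alone.

In an ADME assay on RAW264.7 cells (Mus musculus) for cytotoxicity, read by neutral red uptake, with a stated time of 24 h (a higher number here means that more compound is tolerated, a lower number that less compound is tolerated), compound 1 (`C=CCONC(=O)C(C)N1C(=O)S/C(=C\c2ccccc2)C1=O`) gives > 128000 nM, which is a limit of the assay and not a number. Compound 2 (`C=CCONC(=O)C(C)N1C(=O)S/C(=C\c2ccc(C(F)(F)F)cc2)C1=O`) gives > 128000 nM, which is also a limit. Compound 1 therefore stands at the limit of > 128000 nM in this assay, at which 2 of the 2 values shown sit. Among the measured compounds shown here, the one measured step, a step that the two limits leave unreadable from compound 1 to compound 2, puts trifluoromethyl in place of hydrogen on an aromatic carbon, and it has no readable size.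

Compound 3 (`C=CCONC(=O)C(C)N1C(=O)S/C(=C\CCCC)C1=O`) has not yet been measured. It carries butyl in place of phenyl on a double-bonded chain carbon bound to a double-bonded ring carbon. For the measured compounds named here, no measured step replaces the phenyl, so the only guide is indirect: compound 2, at > 128000 nM, gives no sign of less tolerance in this assay. No step beyond the scatter is therefore expected, and the estimated step is a number no higher from compound 1 to compound 3 (the limit leaves the size open). Any readable move would have to be towards less tolerance, since the starting value is a limit. Compound 3 is expected to lie near 128000 nM, with an estimated range from 50000 nM to 256000 nM.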

Compound 3, half-maximal cytotoxic concentration: > 128000 nM
Compound 3 ended at the assay's limit (the forecaster's own chance of this, stated with the estimate: 75%); the middle value sits exactly at the limit.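

Compound 3, like compound 1 and compound 2, gives a limit of the assay and not a number, so the steps between them cannot be read: the limit of > 128000 nM in this assay, at which 3 of the 3 values shown sit.

The compounds shown leave open at what concentration any of them reaches half-maximal cytotoxicity in this assay, and so whether butyl in place of phenyl changes tolerance at all.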